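Phenoxy in Place of Phenyl on a Receptor Agonist

A few compounds are considered here, and "the series" means these few. Any claim that something is new, unique, unknown or untested is made for them only; others in the source may bear on it.

Of the compounds shown here, two have so far been measured in an in vitro functional assay on 1321-N1 cells for agonist activity at Free fatty acid receptor 1 (Homo sapiens), read by fluorescence, spectrophotometry and calcium flux; a higher number here means a larger maximal response, a lower number a smaller maximal response. Compound 1 `Cc1cc(C#Cc2ccc(CCC(=O)O)cc2)nc(Cl)n1` reaches 110%. Compound 2 `O=C(O)CCc1ccc(C#Cc2ccnc(-c3ccccc3)c2)cc1` gives 97%, the lower of the two numbers, and its gap to compound 1 lies beyond the usual scatter. Compound 3 `O=C(O)CCc1ccc(C#Cc2ccnc(Oc3ccccc3)c2)cc1` has not yet been measured; it differs from compound 2 by phenoxy in place of phenyl on an aromatic carbon. Going by the values given here, no measured pair shows this change, so the expected step in this assay is small, likely no larger than the scatter, in either direction. Compound 3 is estimated to reach 95%, between 78% and 112%, an expected step of a number 2 percentage points lower from compound 2 to compound 3 (within the scatter).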

Compound 3, largest response reached (reported as efficacy), in percent of the reference or control that the assay uses: 94%
For compound 3 the middle estimate is 1 percentage points above the measured one; the range from low to high includes it.
By their numbers in this assay, from the lowest: compounds 3 and 2 (each within the scatter of the next); then compound 1.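

In this assay, phenoxy in place of phenyl on the aromatic carbon next to the ring nitrogen gives a number 3 percentage points lower from compound 2 to compound 3 (within the scatter) on the shared core. The maximal response therefore cannot tell these two groups apart, so this position accepts the ring attached through an oxygen as well as directly. Nothing measured here accounts for this result. Still open, from the compounds shown here alone, is whether an amine linking the same ring, or a benzyloxy group with a longer link, would also hold the response in this assay.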